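Ester in Place of Cyclopropyl on the Fused Ring

The source may hold more compounds than are shown below. What is called first, only, known or untested is meant among the compounds shown, and "the series" means these compounds.

Of the compounds shown here, three sharing one core have been measured in an assay on isolated protein for inhibition of tyrosine-protein kinase receptor UFO (Homo sapiens), read by FRET and Z'-LYTE, with a stated time of 1.5 h; on this read-out higher numbers stand for weaker inhibition and lower numbers for stronger inhibition. Compound 1 `Cc1ccc2[nH]c(C)c(C(=O)Nc3ccc(Oc4ncnc5[nH]cc(-c6ccccc6)c45)c(F)c3)c(=O)c2c1` gives 560 nM, compound 2 `CCc1ccc2c(c1)c(=O)c(C(=O)Nc1ccc(Oc3ncnc4[nH]cc(-c5ccccc5)c34)cc1F)c(C)n2C` gives 30 nM, and compound 3 `Cc1c(C(=O)Nc2ccc(Oc3ncnc4[nH]cc(-c5ccccc5)c34)c(F)c2)c(=O)c2cc(C3CC3)ccc2n1C` gives 230 nM. Compound 3 stands second highest of the three numbers: its nearest neighbour is compound 1, whose value lies beyond the scatter above it, and its furthest is compound 2, whose value lies well beyond the scatter below it. Compound 4 `COC(=O)c1ccc2c(c1)c(=O)c(C(=O)Nc1ccc(Oc3ncnc4[nH]cc(-c5ccccc5)c34)c(F)c1)c(C)n2C` differs from compound 3 only by methoxycarbonyl in place of cyclopropyl on an aromatic carbon. Within the data shown here, no measured pair shows this change, so the account rests on the structural difference alone. A step no larger than the scatter, leaning if anything toward weaker inhibition, is expected for a 1.4-fold higher number from compound 3 to compound 4 (0.14 log units; within the scatter). Compound 4 is therefore estimated at 320 nM, within 90 nM to 1200 nM.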

Compound 4, half-maximal inhibitory concentration: > 10000 nM
Compound 4 ended at the assay's limit; the forecaster's own chance of this, stated with the estimate: 3%; at least 31-fold (1.49 log units) between middle value and limit.
By their numbers in this assay, from the lowest: compound 2; then compound 3; then compound 1. At a limit, above all of these: compound 4.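

Methoxycarbonyl in place of cyclopropyl on this aromatic carbon gives an at least 43-fold higher number from compound 3 to compound 4 (1.63 log units; beyond the scatter), the first step read at this position, and it shows that the position does not accept every group. Compound 4 stands at > 10000 nM, which is a limit and not a number. The step therefore gives only a floor for the change, and its full size stays unknown: the limit of > 10000 nM in this assay, at which 1 of the 4 values shown sits.

Whether the ester itself accounts for this step stays open. How a carboxylic acid, a primary amide or a methoxy group on this carbon would read remains unknown from the compounds shown.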